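Reshaping the acid-bearing chain of compound 3

The source may report more compounds than this note shows. Statements on the series, on what has been measured and on what is new or still open speak of the compounds shown alone.

Compound 3 `CC(C)(CC(=O)Nc1cccc(OCc2ccc3ccc(F)cc3n2)c1)C(=O)O` stands second highest of the three numbers in a functional assay on ileum (Cavia porcellus) for antagonist activity at cysteinyl leukotriene receptor (Homo sapiens) (on this read-out lower numbers stand for stronger inhibition and higher numbers for weaker inhibition), where compound 3 gives 1.4 nM. Compound 1 `CCC(CC)(CC(=O)Nc1cccc(OCc2ccc3ccc(Cl)cc3n2)c1)C(=O)O` gives 0.8 nM, within the scatter of compound 3, while compound 2 `CCC(CC)(CC(=O)Nc1cccc(OCc2ccc3ccc(C(F)(F)F)cc3n2)c1)C(=O)O` gives 3 nM, beyond it. Among the compounds with values here, the only single-place step recorded, a 3.8-fold higher number from compound 1 to compound 2 (0.57 log units; beyond the scatter), concerns the substituent on the aromatic carbon, not the chain. Compound 4 `CCC(CC)(CC(=O)O)C(=O)Nc1cccc(OCc2ccc3ccc(F)cc3n2)c1` differs from compound 3 in that chain: 1-(carboxymethyl)-1-ethylpropyl in place of 2-carboxy-2-methylpropyl on a carbonyl carbon. Within the data shown here, no measured step bears on this change; compound 1 and compound 3, which differ in two places, show values within the scatter of each other. The step expected is a 2.1-fold higher number from compound 3 to compound 4 (0.33 log units; beyond the scatter), a modest weakening. Compound 4 is expected to give 3 nM, within 0.8 nM to 12 nM.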

Compound 4, half-maximal inhibitory concentration: 140 nM
Compound 4: the middle estimate sits 47-fold (1.67 log units) below what was measured, and the stated range ends below it.
By their numbers in this assay, from the lowest: compounds 1 and 3 (each within the scatter of the next); then compound 2; then compound 4.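

The chain change brings a 100-fold higher number from compound 3 to compound 4 (2.00 log units; beyond the scatter), the only large step among these compounds, whereas the one earlier step, on the aromatic carbon, was modest. This position on the carbonyl carbon therefore tolerates far less than the earlier numbers could show, and the 1-(carboxymethyl)-1-ethylpropyl chain costs much of the inhibition. No available evidence accounts for this loss. The step both enlarges and reshapes the chain, so the two changes cannot be told apart here. On these data alone, how a 1-(carboxymethyl)-1-methylethyl chain on the same core would read remains open.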